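Heteroaryl swap on the benzyl arm of compound 3

A few compounds are considered here, and "the series" means these few. Any claim that something is new, unique, unknown or untested is made for them only; others in the source may bear on it.

Measured compounds:
- compound 1, `CSc1cc(C)nc(SC)c1NC(=O)N(Cc1ccccc1)Cc1ccc(-c2cc[nH]n2)cc1`: 55 nM
- compound 2, `O=C(Nc1c(F)cc(F)cc1F)N(Cc1ccc(-c2ccsc2)cc1)C1CCCCCC1`: 23 nM
- compound 3, `Cc1cc(C)c(NC(=O)N(Cc2ccc(-c3ccsc3)cc2)C2CCCCCC2)c(C)c1`: 19 nM

Three ureas were tested in an assay on microsomes from intestine for inhibition of acyl-CoA:cholesterol acyltransferase (Oryctolagus cuniculus); a lower number here means a stronger inhibitor, a higher number a weaker inhibitor. Compound 1 `CSc1cc(C)nc(SC)c1NC(=O)N(Cc1ccccc1)Cc1ccc(-c2cc[nH]n2)cc1` gives 55 nM. Compound 2 `O=C(Nc1c(F)cc(F)cc1F)N(Cc1ccc(-c2ccsc2)cc1)C1CCCCCC1` gives 23 nM, and compound 3 `Cc1cc(C)c(NC(=O)N(Cc2ccc(-c3ccsc3)cc2)C2CCCCCC2)c(C)c1` gives 19 nM. Compound 3 has the lowest number of the three; its gap to compound 2 lies within the scatter, while its gap to compound 1 lies beyond it. Among the compounds with values here, the only single-point step available, a 1.2-fold lower number from compound 2 to compound 3 (0.08 log units; within the scatter), concerns the group on the amide-type nitrogen, not the biaryl arm.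

Compound 4 `Cc1cc(C)c(NC(=O)N(Cc2ccc(-c3ccn(C)n3)cc2)C2CCCCCC2)c(C)c1` differs from compound 3 only in that arm: 1-methyl-1H-pyrazol-3-yl in place of thiophen-3-yl on an aromatic carbon. Within the data shown here, no measured step in this set changes that position alone. Compound 1 carries a pyrazolyl group there, but it also differs from compound 3 in the benzyl group and in the aryl on the urea, so its higher number cannot be attributed to the heteroaryl. The step from compound 3 to compound 4 is therefore expected to be small, most likely a modest rise in this assay: a 1.8-fold higher number from compound 3 to compound 4 (0.27 log units; within the scatter). Compound 4 is estimated at 35 nM, with a range from 12 nM to 110 nM.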

Compound 4, half-maximal inhibitory concentration: 44 nM
Compound 4: the middle estimate sits 1.3-fold (0.10 log units) below what was measured; the measured number falls inside the stated range.
By their numbers in this assay, from the lowest: compounds 3, 2, 4 and 1 (each within the scatter of the next, the first and the last beyond it).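

In this assay, the exchange of thiophen-3-yl for 1-methyl-1H-pyrazol-3-yl gives the first step read at this position alone, a 2.3-fold higher number from compound 3 to compound 4 (0.36 log units; beyond the scatter), and it shows that the aryl group para to a large group does affect the number when everything else stays fixed. The effect is modest, however: the entering ring has one more hetero atom and one more hydrogen-bond acceptor than the one it replaces, and compound 4 still gives 44 nM. No independent measurement in this set bears on what lies behind the rise, so the step stands as an observation for this one pair.

The pair changes the ring atoms and adds the methyl group on nitrogen in a single step, so the share of each in the rise stays unresolved, and the compounds shown do not say how a plain phenyl, a pyridin-3-yl ring or a dimethylamino group would fare at this position. On these data alone, whether the same step would hold with the 2,4,6-trifluorophenyl group of compound 2 on the urea also remains open.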